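Swapping the sulfonyl aryl group: from dichloro to difluoro

A few compounds are considered here, and "the series" means these few. Any claim that something is new, unique, unknown or untested is made for them only; others in the source may bear on it.

Measured so far:
Compound 1 `COc1cccc(S(=O)(=O)c2cnc3cc(F)ccc3c2-c2cccc(F)c2)c1`: 3.36 mL/min
Compound 2 `O=S(=O)(c1cc(F)cc(F)c1)c1cnc2cc(F)ccc2c1-c1cccc(F)c1`: 0.06 mL/min
Compound 3 `O=S(=O)(c1cc(Cl)cc(Cl)c1)c1cnc2cc(F)ccc2c1-c1cccc(F)c1`: 0.41 mL/min

The three compounds share one core and differ only in the aryl group on the sulfonyl sulfur. In an ADME assay on microsomes from liver (Homo sapiens) for metabolic stability, tested at 2.5 uM (on this read-out lower numbers stand for slow clearance and higher numbers for fast clearance), compound 1 gives 3.36 mL/min, the highest of the three numbers, while compound 2 gives 0.06 mL/min, the lowest. Compound 3 gives 0.41 mL/min and stands second highest; its nearest neighbour is compound 2 a 6.8-fold higher number from compound 2 to compound 3 (0.83 log units; beyond the scatter) and its furthest is compound 1 an 8.2-fold lower number from compound 1 to compound 3 (0.91 log units; beyond the scatter). The step from the methoxy compound to the difluoro compound was the largest seen a 56-fold lower number from compound 1 to compound 2 (1.75 log units; beyond the scatter).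

Compound 4 `O=S(=O)(c1ccc(F)c(F)c1)c1cnc2cc(F)ccc2c1-c1cccc(F)c1` is not yet measured. It differs from compound 3 in one place: 3,4-difluorophenyl in place of 3,5-dichlorophenyl on a sulfonyl sulfur. The step that bears most directly on this change is the one between the two dihalo compounds a 6.8-fold higher number from compound 2 to compound 3 (0.83 log units; beyond the scatter), which shows that trading chlorine for fluorine on this ring is enough to move the number beyond the scatter. Compound 4 carries two fluorines, as compound 2 does, though in a different arrangement, so it is expected to sit nearer compound 2 than compound 3 in this assay, with a lower number expected for compound 4 than for compound 3 a 4.1-fold lower number from compound 3 to compound 4 (0.61 log units; beyond the scatter). Compound 4 is therefore estimated at 0.1 mL/min, within a range of 0.03 mL/min to 0.4 mL/min.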

Compound 4, intrinsic clearance in a liver preparation (reported as CLH), per the amount of preparation that the assay uses: 0.6 mL/min
The estimate for compound 4 lay 6.0-fold (0.78 log units) below the measured number; the whole stated range lies below it.
By their numbers in this assay, from the lowest: compound 2; then compounds 3 and 4 (each within the scatter of the next); then compound 1.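

In this assay, moving the two fluorines from the 3,5-difluorophenyl group of compound 2 to the 3,4-difluorophenyl group of compound 4 gives a 10-fold higher number from compound 2 to compound 4 (1.00 log units; beyond the scatter), so at this position on the sulfonyl sulfur the arrangement of the halogens matters and not only their identity. The change from 3,5-dichlorophenyl to 3,4-difluorophenyl gives a 1.5-fold higher number from compound 3 to compound 4 (0.17 log units; within the scatter), so these two compounds cannot be told apart, even though the halogen and its arrangement both differ, and the low number of compound 2 does not extend to every difluorophenyl group. Compound 4 still improves on the 3-methoxyphenyl compound, with a 5.6-fold lower number from compound 1 to compound 4 (0.75 log units; beyond the scatter), which places both compound 3 and compound 4 in a middle band between compound 1 and compound 2.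

Nothing measured here accounts for why the 3,5-difluorophenyl group stands apart from the other aryl groups. Also open is how this position would respond to an aryl ring carrying a nitrile, an amine or a carboxylic acid, since every group shown so far is a halogenated or methoxy-bearing phenyl.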